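The source may hold more compounds than are shown below. What is called first, only, known or untested is meant among the compounds shown, and "the series" means these compounds.

Of the compounds shown here, two have been read so far. Compound 1 `C#Cc1cc(C(=O)NCCCCc2ccccc2)cc(C2SCC(=O)N2c2ccccc2OC)c1` and compound 2 `Cc1cccc(N2C(=O)CSC2c2cccc(C(=O)NCCCCc3ccccc3)c2)c1` share the same core and the same amide chain. In an ADME assay on microsomes from liver (Rattus norvegicus) for metabolic stability, read by LC-MS, using NADPH, with a stated time of 10 min, tested at 0.1 uM (on this read-out lower numbers stand for slow clearance and higher numbers for fast clearance), compound 1 gives 2200 mL.min-1.g-1. In this assay compound 2 gives 3140 mL.min-1.g-1. For the measured compounds named here, compound 2 shows the highest of the two numbers measured so far; the nearest is compound 1, and that gap falls within the scatter, so the two are not told apart on this assay.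

The next compound is compound 3 `O=C(NCCCCc1ccccc1)c1cccc(C2SCC(=O)N2c2ccccn2)c1`. It differs from compound 2 in one place: pyridin-2-yl in place of 3-methylphenyl on an amide-type nitrogen in a ring. Going by the values given here, no measured pair carries this change, so nothing is known of its effect on clearance. Both measured numbers lie in the fast-clearance region of this assay, and the change leaves the amide chain untouched. The step is therefore expected to be small, a 1.3-fold lower number from compound 2 to compound 3 (0.10 log units; within the scatter), with no direction beyond the scatter. Compound 3 is estimated at 2500 mL.min-1.g-1 in this assay, within a range from 1200 mL.min-1.g-1 to 5000 mL.min-1.g-1.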

Compound 3, intrinsic clearance in microsomes: 1480 mL.min-1.g-1
Compound 3: middle estimate off by 1.7-fold (0.23 log units), on the high side, and the stated range covers the measured number.
By their numbers in this assay, from the lowest: compounds 3, 1 and 2 (each within the scatter of the next, the first and the last beyond it).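

In this assay, the group on the amide-type nitrogen in a ring now has its first readable step: pyridin-2-yl in place of 3-methylphenyl gives a 2.1-fold lower number from compound 2 to compound 3 (0.33 log units; beyond the scatter), a modest change that lies beyond the scatter. The clearance read-out therefore responds to a change at this one position while the amide chain and the rest of the shared core stay the same, something compound 1 and compound 2 could not show, as they differ in more than one place. Nothing available accounts for this step, which rests on a single pair.

From the compounds shown here alone, it remains open whether the step belongs to the ring nitrogen of the pyridin-2-yl group, to the loss of the methyl group, or to both, and whether it would carry over to the background of compound 1. A plain phenyl or a pyridin-3-yl group at this position would separate these readings, while a carboxylic acid or an amine on the ring would test how far the read-out can move from here.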